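This account rests on a few compounds, and the source may have more. Where it says the series, first, only, none or still open, it means among the compounds named here.

Of the compounds shown here, three sharing one core have been measured in a functional assay on A549 cells (Homo sapiens) for inhibition, read by MTT assay, with a stated time of 72 h, tested at 10 uM; a lower number here means less inhibition, a higher number more inhibition at the concentration tested (going by the name of the read-out). Compound 1 `CCOC(=O)C1=C(Nc2ccccc2)S/C(=C\c2ccccc2)C1=O` gives 29.6% in this assay. Compound 2 `CCOC(=O)C1=C(Nc2ccccc2)S/C(=C\c2ccc(OC)cc2)C1=O` gives 17.5% in this assay. Compound 3 `CCOC(=O)C1=C(Nc2ccccc2)S/C(=C\c2ccc(Br)c(O)c2)C1=O` gives 13.6% in this assay, the lowest of the three numbers shown, though its gap to compound 2 lies within the scatter while the step of a number 16 percentage points lower from compound 1 to compound 3 (beyond the scatter) lies beyond it. The steps on this position are a number 12.1 percentage points lower from compound 1 to compound 2 (beyond the scatter) and a number 3.9 percentage points lower from compound 2 to compound 3 (within the scatter).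

Compound 4 `CCOC(=O)C1=C(Nc2ccccc2)S/C(=C\c2ccc(C(=O)O)cc2)C1=O` is not yet measured. It differs from compound 3 as 4-carboxyphenyl in place of 4-bromo-3-hydroxyphenyl on a double-bonded chain carbon bound to a double-bonded ring carbon. Both steps of a number 12.1 percentage points lower from compound 1 to compound 2 (beyond the scatter) and a number 16 percentage points lower from compound 1 to compound 3 (beyond the scatter) fell when a substituted phenyl replaced phenyl, and the step of a number 3.9 percentage points lower from compound 2 to compound 3 (within the scatter) between two substituted phenyls stayed within the scatter, so a further substituted phenyl is expected to sit close to compound 3 in this assay. The step of a number 1.4 percentage points higher from compound 3 to compound 4 (within the scatter) is therefore expected to remain within the scatter. Compound 4 is expected to give 15% in this assay, between 3% and 30%.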

Compound 4, a percentage reported as inhibition, at one concentration (the size of the read-out at that concentration, not a potency): 11.6%
The estimate for compound 4 lay 3.4 percentage points above the measured number; low and high end bracket the measured number.
By their numbers in this assay, from the lowest: compounds 4, 3 and 2 (each within the scatter of the next); then compound 1.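

In this assay, the 4-carboxyphenyl group falls in with the other substituted phenyls: the step of a number 2 percentage points lower from compound 3 to compound 4 (within the scatter) and the step of a number 5.9 percentage points lower from compound 2 to compound 4 (within the scatter) leave compound 2, compound 3 and compound 4 within the scatter of each other. The step of a number 18 percentage points lower from compound 1 to compound 4 (beyond the scatter) adds a third case, after methoxy and 4-bromo-3-hydroxyphenyl, in which a substituted phenyl at this place reads beyond the scatter from compound 1, and none of the four compounds goes against this. Nothing available explains why these three different substitutions read alike.

On these data alone, whether an amine or a longer alkyl chain on this aromatic carbon would stay with this group remains open. Single-concentration numbers also leave open how the four compounds compare in potency.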